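Moving the amine along a six-atom side chain

The source may report more compounds than this note shows. Statements on the series, on what has been measured and on what is new or still open speak of the compounds shown alone.

Compound 3 `CC(C)(CCN)CN(C[C@H]1Cc2ccccc2CN1)[C@H]1CCCc2cccnc21` carries the shared core and a side chain of six heavy atoms on a saturated chain carbon bound to an amine nitrogen. In a functional assay on cells for agonist activity at C-X-C chemokine receptor type 4 (Homo sapiens), read by fluorescence and calcium flux, with a stated time of 90 s (a higher number here means that more compound is needed for the effect, a lower number that less compound is needed), compound 3 gives > 30000 nM, which is a limit of the assay rather than a number. Two relatives keep the same core and change the same side chain. Compound 1 `c1ccc2c(c1)CN[C@@H](CN(CCCCNCc1ccncc1)[C@H]1CCCc3cccnc31)C2` gives > 30000 nM in this assay, again a limit. Compound 2 `c1ccc2c(c1)CN[C@@H](CN(CCCCNCC1CCCCC1)[C@H]1CCCc3cccnc31)C2` gives > 30000 nM in this assay, also a limit. The steps among them, a step that the two limits leave unreadable from compound 1 to compound 2, a step that the two limits leave unreadable from compound 1 to compound 3 and a step that the two limits leave unreadable from compound 2 to compound 3, cannot be sized because of the limit of > 30000 nM in this assay, at which 3 of the 3 values shown sit.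

Compound 4 `CC(C)(N)CCCN(C[C@H]1Cc2ccccc2CN1)[C@H]1CCCc2cccnc21` has not yet been measured. It differs from compound 3 only in how the same atoms are joined: a group of 6 heavy atoms (5 carbon, 1 nitrogen; no ring) in place of a group of 6 heavy atoms (5 carbon, 1 nitrogen; no ring), on a saturated chain carbon bound to an amine nitrogen. Among the measured compounds shown here, no measured step covers such a rearrangement, and the three steps that do exist are unreadable, so neither a direction nor a size can be taken from them. The expected step that the limit leaves unreadable from compound 3 to compound 4 is small, with compound 4 expected to remain at the limit. Compound 4 is therefore estimated at 50000 nM, with a range from 20000 nM to 200000 nM.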

Compound 4, half-maximal effective concentration: > 30000 nM
Compound 4: a limit, no number (the forecaster's own chance of this, stated with the estimate: 85%); the middle value is on the limit's open side.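

Compound 4 also gives a limit rather than a number, so none of its steps to compound 1, compound 2 or compound 3 can be read, because all of these compounds share one limit: the limit of > 30000 nM in this assay, at which 4 of the 4 values shown sit. The compounds shown leave open how large any of these side-chain changes really is in this assay.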